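This account rests on a few compounds, and the source may have more. Where it says the series, first, only, none or still open, it means among the compounds named here.

Measured so far in an ADME assay on RAW264.7 cells (Mus musculus) for cytotoxicity, read by MTT assay, with a stated time of 24 h; on this read-out lower numbers stand for higher toxicity in this test and higher numbers for lower toxicity in this test:

Compound 1 `COc1ccccc1C(=O)Nc1ccc(Cl)cc1F`; in this assay compound 1 gives > 40000 nM, a limit of the assay.
Compound 2 `O=C(Nc1ccc(Cl)cc1F)c1ccccc1`; compound 2 gives > 40000 nM, also a limit.
Compound 3 `COc1ccc(C(=O)Nc2ccc(I)cc2F)c(OC)c1`; compound 3 gives > 40000 nM, again a limit.

For the measured compounds named here, every value so far sits at the limit of > 40000 nM in this assay, at which 3 of the 3 values shown sit, so no number is yet known for any member of the series. The step that the two limits leave unreadable from compound 1 to compound 2 therefore cannot be read; the change behind it is hydrogen in place of methoxy on an aromatic carbon. The difference between the cores of compound 1 and compound 3 is not broken down here.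

Compound 4 `COc1ccc(C(=O)Nc2ccc(I)cc2F)cc1` has not yet been measured. It differs from compound 3 by hydrogen in place of methoxy on an aromatic carbon, the same kind of change as that from compound 1 to compound 2; the place differs in that the carbon is here also meta to a methoxy group, in addition to being ortho to a large group.

The step from compound 3 to compound 4 in this assay is expected to be a step that the limit leaves unreadable from compound 3 to compound 4, an expectation that rests on compound 1, compound 2 and compound 3 all sitting at the limit of > 40000 nM in this assay, at which 3 of the 3 values shown sit. Compound 4 is accordingly expected to give 60000 nM, estimated between 30000 nM and 150000 nM.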

Compound 4, half-maximal cytotoxic concentration: 32800 nM
Compound 4: the middle estimate sits 1.8-fold (0.26 log units) above what was measured; the range from low to high includes it.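

In this assay, for the compounds shown here, hydrogen in place of methoxy on an aromatic carbon gives an at least 1.2-fold lower number from compound 3 to compound 4 (0.08 log units; that floor lies within the scatter), so on the core of compound 3 the change brings the series to its only numerical value, while the true size of the step remains open and could exceed this floor. That floor does not show a change beyond the usual scatter, and so it does not establish that removing this methoxy group raises toxicity in this test. Nor can the result be set against the same change on the core of compound 1, as that step cannot be read and whether the change carries from one core to the other stays unresolved: the limit of > 40000 nM in this assay, at which 3 of the 4 values shown sit.

The compounds shown leave open whether a readable step would appear on the core of compound 1, where both ends are limits. They also leave open how this aromatic carbon would respond to a group other than hydrogen or methoxy, such as an amine or a carboxylic acid.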